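The source may report more compounds than this note shows. Statements on the series, on what has been measured and on what is new or still open speak of the compounds shown alone.

Measured compounds in a functional assay on CCRF-CEM cells (Homo sapiens) for antiproliferative activity, with a stated time of 72 h; on this read-out lower numbers stand for stronger inhibition and higher numbers for weaker inhibition:
compound 1 `OC[C@H]1O[C@@H](n2cnc3c(NCc4ccc(F)cc4)ncnc32)[C@H](O)[C@@H]1O` gives 1250 nM
compound 2 `OC[C@H]1O[C@@H](n2cnc3c(NCc4ccccc4Br)ncnc32)[C@H](O)[C@@H]1O` gives 12300 nM
compound 3 `OC[C@H]1O[C@@H](n2cnc3c(NCc4ccc(F)c(F)c4F)ncnc32)[C@H](O)[C@@H]1O` gives 58200 nM

Compound 1 stands lowest of the three in this assay; compound 2 is nearest and compound 3 furthest from it.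

Compound 4 `Cc1cccc(CNc2ncnc3c2ncn3[C@@H]2O[C@H](CO)[C@@H](O)[C@H]2O)c1O` is not yet measured. It differs from compound 1 in one place: 2-hydroxy-3-methylphenyl in place of 4-fluorophenyl on a saturated chain carbon bound to a nitrogen on an aromatic ring.

Going by the values given here, two measured steps bear on this change, both replacing the 4-fluorophenyl of compound 1 on the saturated chain carbon bound to a nitrogen on an aromatic ring. The step of a 9.8-fold higher number from compound 1 to compound 2 (0.99 log units; beyond the scatter) and the step of a 47-fold higher number from compound 1 to compound 3 (1.67 log units; beyond the scatter) both moved the number up, beyond the scatter. Compound 4 likewise departs from 4-fluorophenyl, and the entering group carries substituents on the ring as the 2-bromophenyl of compound 2 and the 2,3,4-trifluorophenyl of compound 3 do, so a higher number is expected for compound 4, with a step of about a 6.4-fold higher number from compound 1 to compound 4 (0.81 log units; beyond the scatter) expected. For compound 4 the estimate in this assay is 8000 nM, expected to lie between 2500 nM and 30000 nM.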

Compound 4, half-maximal inhibitory concentration: 900 nM
The estimate for compound 4 lay 8.9-fold (0.95 log units) above the measured number, and the stated range ends above it.
By their numbers in this assay, from the lowest: compounds 4 and 1 (each within the scatter of the next); then compound 2; then compound 3.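

In this assay, leaving 4-fluorophenyl on the saturated chain carbon bound to a nitrogen on an aromatic ring need not raise the number: 2-hydroxy-3-methylphenyl gives a 1.4-fold lower number from compound 1 to compound 4 (0.14 log units; within the scatter) and so cannot be told apart from the group it replaces. The entering group therefore decides the outcome, not merely the loss of 4-fluorophenyl, since 2-hydroxy-3-methylphenyl in place of 2-bromophenyl gives a 14-fold lower number from compound 2 to compound 4 (1.14 log units; beyond the scatter) and in place of 2,3,4-trifluorophenyl gives a 65-fold lower number from compound 3 to compound 4 (1.81 log units; beyond the scatter) in this series. No measurement at hand accounts for this separation among the rings.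

From the compounds shown here alone, the hydroxyl and the methyl enter together in compound 4, so their separate shares stay open. A 2-hydroxybenzyl or 3-methylbenzyl group, or a methoxy or an amine in place of the hydroxyl, would address this.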